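This account rests on a few compounds, and the source may have more. Where it says the series, first, only, none or still open, it means among the compounds named here.

For the measured compounds named here, compound 3 `CC[Si](CC)(CC)C/C1=C/C[C@](C)(CCC=C(C)C)/C=C/[C@@H](OC(=O)C=C(C)C)[C@](C)(O)/C=C/C1=O` sits second highest of the three numbers so far in a functional assay on SMMC-7721 cells (Homo sapiens) for antiproliferative activity, read by MTT assay, with a stated time of 48 h; on this read-out lower numbers stand for stronger inhibition and higher numbers for weaker inhibition. Compound 1 `COC/C1=C/C[C@](C)(CCC=C(C)C)/C=C/[C@@H](OC(=O)C=C(C)C)[C@](C)(O)/C=C/C1=O` gives 11000 nM, compound 2 `CC(C)=CCC[C@]1(C)/C=C/[C@@H](OC(=O)C=C(C)C)[C@](C)(O)/C=C/C(=O)/C(CN(C)C)=C\C1` gives 820 nM, and compound 3 gives 3460 nM; the nearest is compound 1, with a 3.2-fold lower number from compound 1 to compound 3 (0.50 log units; beyond the scatter), and the furthest is compound 2, with a 4.2-fold higher number from compound 2 to compound 3 (0.63 log units; beyond the scatter). Compound 4 `CSC(=S)OC/C1=C/C[C@](C)(CCC=C(C)C)/C=C/[C@@H](OC(=O)C=C(C)C)[C@](C)(O)/C=C/C1=O` differs from compound 3 at the same place that all three measured compounds vary: a group of 5 heavy atoms (2 carbon, 1 oxygen, 2 sulfur; no ring) in place of a group of 7 heavy atoms (6 carbon, 1 silicon; no ring), on a saturated chain carbon bound to a double-bonded ring carbon. Going by the values given here, the steps that bear on this are the two at that position, a 3.2-fold lower number from compound 1 to compound 3 (0.50 log units; beyond the scatter) and a 13-fold lower number from compound 1 to compound 2 (1.13 log units; beyond the scatter), both beyond the scatter and pointing in opposite directions from the shared core of compound 1. The entering group shares an oxygen with the methoxy of compound 1 and is larger than it, so a number between those of compound 1 and compound 3 is expected, meaning a modest rise from compound 3, about a 1.4-fold higher number from compound 3 to compound 4 (0.16 log units; within the scatter). Compound 4 is therefore estimated at 5000 nM in this assay, in a range from 1500 nM to 15000 nM.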

Compound 4, half-maximal inhibitory concentration: 720 nM
Compound 4: the middle estimate sits 6.9-fold (0.84 log units) above what was measured; measured number below the stated range.
By their numbers in this assay, from the lowest: compounds 4 and 2 (each within the scatter of the next); then compound 3; then compound 1.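

In this assay the group of 5 heavy atoms (2 carbon, 1 oxygen, 2 sulfur; no ring) gives a 4.8-fold lower number from compound 3 to compound 4 (0.68 log units; beyond the scatter) in place of the silicon-bearing group. With the oxygen on the saturated carbon kept, a sulfur-bearing group in place of one carbon atom gives a 15-fold lower number from compound 1 to compound 4 (1.18 log units; beyond the scatter) as a large step, so sharing that oxygen does not keep compound 4 close to compound 1. The step of a 1.1-fold lower number from compound 2 to compound 4 (0.06 log units; within the scatter) leaves the two compounds indistinguishable, which shows that a group without the nitrogen of dimethylamino can reach the same level at this place.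

Going by these compounds, whether a primary amine, a carboxylic acid or a longer chain on this saturated chain carbon would do the same remains open. Nothing shown here accounts for the size of these steps.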